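Adding a chloro to a hydrazone aryl: compound 2 to 4

This account rests on a few compounds, and the source may have more. Where it says the series, first, only, none or still open, it means among the compounds named here.

Compound 1, `CN(C(=O)NC(=O)c1ccc(Cl)cc1Cl)c1nc(C(F)(F)F)c(C(=O)N/N=C/c2cccc(C(F)(F)F)c2)s1`, gives 11.2 ug/mL in a functional assay on HepG2 cells (Homo sapiens) for inhibition, read by MTT assay, with a stated time of 72 h; a lower number here means a stronger inhibitor, a higher number a weaker inhibitor.
Compound 2, `Cc1nc(N(C)C(=O)NC(=O)c2c(F)cccc2F)sc1C(=O)N/N=C/c1ccc(Cl)cc1`, gives > 100 ug/mL in this assay.
Compound 3, `CN(C(=O)NC(=O)c1ccc(Cl)c(Cl)c1)c1nc(C(F)(F)F)c(C(=O)N/N=C/c2ccc([N+](=O)[O-])cc2)s1`, gives 6.85 ug/mL in this assay.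

Compound 2 stands at the limit of > 100 ug/mL in this assay, at which 1 of the 3 values shown sits, so it has no number of its own, only a limit. Compound 4, `Cc1nc(N(C)C(=O)NC(=O)c2c(F)cccc2F)sc1C(=O)N/N=C/c1ccc(Cl)cc1Cl`, differs from compound 2 in one place: chloro in place of hydrogen on an aromatic carbon. Within the data shown here, compounds 1 and 3 each carry a chloro on an aromatic ring and return measurable numbers, but no measured step joins them to compound 2, so they give no direct guide. With only a limit as the starting point, compound 4 is expected to gain modestly, if at all, and the step from compound 2 to compound 4 is estimated as an at least 1.2-fold lower number from compound 2 to compound 4 (0.09 log units; that floor lies within the scatter). Compound 4 is therefore expected at 80 ug/mL, within 30 ug/mL to 200 ug/mL.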

Compound 4, half-maximal inhibitory concentration: 70 ug/mL
Compound 4: the middle estimate sits 1.1-fold (0.06 log units) above what was measured; the measured number falls inside the stated range.
By their numbers in this assay, from the lowest: compounds 3 and 1 (each within the scatter of the next); then compound 4. At a limit, above all of these: compound 2.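

Compound 2 has only a limit, not a number of its own: the limit of > 100 ug/mL in this assay, at which 1 of the 4 values shown sits.

Going from 4-chlorophenyl to 2,4-dichlorophenyl gives an at least 1.4-fold lower number from compound 2 to compound 4 (0.15 log units; that floor lies within the scatter), so in this assay this change yields a readable number, though its true size stays unknown and the floor alone proves no gain. Among these compounds, compounds 1 and 3 differ from compound 2 in more than one place, so only this pair speaks to the new chloro.

Still open, as far as these compounds go, is whether a methoxy or an amine on the same aromatic carbon would behave like chloro. From the compounds shown here alone, whether the step carries over to the core of compound 1 is also open.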